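Moving two methyl groups on compound 1

A few compounds are considered here, and "the series" means these few. Any claim that something is new, unique, unknown or untested is made for them only; others in the source may bear on it.

For the measured compounds named here, in an ADME assay on MT4 cells (Homo sapiens) for cytotoxicity, read by MTT assay, with a stated time of 5 days (a higher number here means that more compound is tolerated, a lower number that less compound is tolerated), compound 1 `Cc1cccc(C)c1Oc1cc(Nc2ccc(C#N)cc2)[nH]c(=O)c1Br` gives 63000 nM, the highest of the three numbers so far. Compound 2 `Cc1cccc(C)c1Oc1cc(Nc2ccc(C#N)cc2)[nH]c(=O)c1I` gives 28000 nM, and compound 3 `COc1cc(Oc2c(C)cc(C)cc2C)cc(Nc2ccc([N+](=O)[O-])cc2)n1` gives 7200 nM. Compound 4 `Cc1cc(C)cc(Oc2cc(Nc3ccc(C#N)cc3)[nH]c(=O)c2Br)c1` is still unmeasured, and it carries 3,5-dimethylphenyl in place of 2,6-dimethylphenyl on an oxygen on an aromatic ring. Going by the values given here, the only measured single change is a different one, iodo in place of bromo on an aromatic carbon, and it is modest: a 2.3-fold lower number from compound 1 to compound 2 (0.35 log units; beyond the scatter). Nothing measured tests the new change directly, so the guess is loose. A similar modest move toward a lower number is expected, a 2.1-fold lower number from compound 1 to compound 4 (0.32 log units; beyond the scatter). For compound 4 the estimate is 30000 nM, within an expected range of 10000 nM to 90000 nM.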

Compound 4, half-maximal cytotoxic concentration: 19000 nM
Compound 4: the middle estimate sits 1.6-fold (0.20 log units) above what was measured; the measured number falls inside the stated range.
By their numbers in this assay, from the lowest: compound 3; then compounds 4 and 2 (each within the scatter of the next); then compound 1.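

In this assay, swapping 2,6-dimethylphenyl for 3,5-dimethylphenyl on the oxygen gives a 3.3-fold lower number from compound 1 to compound 4 (0.52 log units; beyond the scatter), so the number responds to where the two methyl groups sit, even though the atoms stay the same. The earlier step showed only a change of halogen, whereas this one shows a rearrangement of the aryl group alone moving the number by a modest amount. Nothing available explains this shift. Still open, on these data alone, is whether the shift holds with iodo in place of bromo, and how ethyl groups or an amine on that ring would behave.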